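The source may hold more compounds than are shown below. What is called first, only, known or untested is meant among the compounds shown, and "the series" means these compounds.

Measured compounds in a functional assay (Homo sapiens) for antiproliferative activity; on this read-out lower numbers stand for stronger inhibition of growth and higher numbers for weaker inhibition of growth:
compound 1 `Cc1cn2c(/C=N/NC(=N)N)c(-c3ccncc3)nc2s1`, 9770 nM
compound 2 `Cc1sc2nc(-c3ccncc3)c(/C=N/NC(=N)N)n2c1C`, 30200 nM
compound 3 `N=C(N)N/N=C/c1c(-c2ccncc2)nc2sc(Cl)cn12`, 3800 nM

Compound 1 stands second highest of the three numbers. Its nearest neighbour is compound 3, reached by a 2.6-fold lower number from compound 1 to compound 3 (0.41 log units; beyond the scatter); its furthest is compound 2, reached by a 3.1-fold higher number from compound 1 to compound 2 (0.49 log units; beyond the scatter). Both measured steps alter the five-membered ring of the shared core, chloro in place of methyl and methyl in place of hydrogen on an aromatic carbon, and leave the pyridin-4-yl group untouched.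

Compound 4 `Cc1cn2c(/C=N/NC(=N)N)c(-c3ccccn3)nc2s1` has not yet been measured in this assay. It differs from compound 1 by pyridin-2-yl in place of pyridin-4-yl on an aromatic carbon. Among the compounds with values here, no measured step concerns this part of the molecule, so the two steps from compound 1 give no direct guide to the size or direction of the step in this assay, and no pattern can be drawn from them for this change. Lacking a bearing comparison, the expectation for compound 4 is a number close to that of compound 1, with a range wide enough to cover steps of the size seen for compound 2 and compound 3 in either direction. The estimated step is a 1.0-fold higher number from compound 1 to compound 4 (0.01 log units; within the scatter). Compound 4 is estimated at 10000 nM, within a range from 3000 nM to 35000 nM.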

Compound 4, concentration for 50% growth inhibition: 3630 nM
For compound 4 the middle estimate is 2.8-fold (0.44 log units) above the measured one; measured number inside the range.
By their numbers in this assay, from the lowest: compounds 4 and 3 (each within the scatter of the next); then compound 1; then compound 2.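

In this assay, the placement of the ring nitrogen in the pyridine substituent matters: pyridin-2-yl in place of pyridin-4-yl gives a 2.7-fold lower number from compound 1 to compound 4 (0.43 log units; beyond the scatter). Within the data shown here, this is the first reading at this position, an aromatic carbon of the five-membered aromatic ring with 2 nitrogen, and it shows that the read-out responds to a change outside the part of the shared core altered by the two earlier steps, even though the swap leaves the atoms of the compound unchanged and the counted donors and acceptors of the group the same. The step is modest but beyond the scatter, and the data shown offer nothing that accounts for it.

Open at this position is how pyridin-3-yl, an unsubstituted phenyl ring or a pyridin-2-yl ring carrying an amine would compare with the pyridin-2-yl group of compound 4. Also open, going by these compounds, is whether the step from pyridin-4-yl to pyridin-2-yl keeps its direction and size when the methyl on the core is replaced by chloro or joined by a second methyl.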